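Exchanging methyl for naphthoyl on the chain of compound 3

The compounds below may be only part of what the source reports. "The series", "measured", "known", "first", "only" and "open" are said of these compounds alone.

Compound 3 `CCSc1nnc(-c2cc(OC)c(OC)c(OC)c2)n1-c1ccc(N(C)C)cc1` was tested in a functional assay on HepG2 cells (Homo sapiens) for inhibition, read by MTT assay, with a stated time of 48 h; on this read-out lower numbers stand for stronger inhibition and higher numbers for weaker inhibition. In this assay compound 3 gives only a limit, > 60000 nM. Compound 1 `COc1ccc(-n2c(SCC(=O)c3ccc(OC)c(O)c3)nnc2-c2cc(OC)c(OC)c(OC)c2)cc1` likewise gives a limit in this assay, > 60000 nM. Compound 2 `COc1ccc(-n2c(SCC(=O)Nc3ccc(Cl)cc3)nnc2-c2cc(OC)c(OC)c(OC)c2)cc1` also gives a limit in this assay, > 60000 nM. Going by the values given here, the single measured step, a step that the two limits leave unreadable from compound 1 to compound 2, is therefore unreadable, and the one firm observation is the limit of > 60000 nM in this assay, at which 3 of the 3 values shown sit. Compound 4 `COc1cc(-c2nnc(SCC(=O)c3ccc4ccccc4c3)n2-c2ccc(N(C)C)cc2)cc(OC)c1OC` differs from compound 3 in one place: (naphthalen-2-yl)carbonyl in place of methyl on a saturated chain carbon bound to a sulfur. Among the compounds with values here, compound 1, which also bears a carbonyl on its chain, sits at the limit, so no measured step gives a direction for this change. Compound 4 is therefore expected to stay near the limit, with an expected step that the limit leaves unreadable from compound 3 to compound 4. The estimate for compound 4 in this assay is 80000 nM, within 15000 nM to 400000 nM.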

Compound 4, half-maximal inhibitory concentration: > 60000 nM
Compound 4 gave a limit, no number (the forecaster's own chance of this, stated with the estimate: 75%); the middle value does not contradict the limit.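

Compound 3 and compound 4 each give only a limit, so no step can be read between them. The compounds shown leave open what effect, if any, exchanging methyl for (naphthalen-2-yl)carbonyl has on inhibition, with one firm observation remaining: the limit of > 60000 nM in this assay, at which 4 of the 4 values shown sit.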